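A few compounds are considered here, and "the series" means these few. Any claim that something is new, unique, unknown or untested is made for them only; others in the source may bear on it.

Working notes on the series. In a functional assay on NCI-H460 cells (Homo sapiens) for antiproliferative activity, with a stated time of 72 h (on this read-out lower numbers stand for stronger inhibition and higher numbers for weaker inhibition), compound 1 `C=CC[C@H]1C[C@]2([C@@H](C)Cc3cc(OC)c(OC)cc3F)OCOC2=CC1=O` gives 120 nM, and compound 2 `C=CC[C@H]1C[C@]2([C@@H](C)Cc3ccc(OC)cc3F)OCOC2=CC1=O` gives 94 nM. Compound 2 holds the lowest of the two numbers, and compound 1 is the nearest, the step being a 1.3-fold lower number from compound 1 to compound 2 (0.11 log units; within the scatter). Compound 3 `C=CC[C@H]1C[C@]2([C@@H](C)Cc3cc(F)c(OC)cc3F)OCOC2=CC1=O` differs from compound 2 by fluoro in place of hydrogen on an aromatic carbon. For the measured compounds named here, no measured step swaps hydrogen for fluoro; the single known step, from methoxy to hydrogen on this ring, stayed within the scatter and bears on the new change only loosely. A step from compound 2 to compound 3 of about a 1.0-fold lower number from compound 2 to compound 3 (0.02 log units; within the scatter) is therefore expected, nothing beyond the scatter. Compound 3 is estimated at 90 nM, with a range of 40 nM to 200 nM.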

Compound 3, half-maximal inhibitory concentration: 59 nM
Estimate against measurement, compound 3: 1.5-fold (0.18 log units) above; the measured number falls inside the stated range.
By their numbers in this assay, from the lowest: compounds 3, 2 and 1 (each within the scatter of the next, the first and the last beyond it).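

In this assay, fluoro is tolerated on this aromatic carbon, ortho to a methoxy group: the change from hydrogen gives a 1.6-fold lower number from compound 2 to compound 3 (0.20 log units; within the scatter), so the two are not told apart here. Fluoro in place of methoxy at the same carbon gives a 2.0-fold lower number from compound 1 to compound 3 (0.31 log units; beyond the scatter), the first modest step in the series to pass the scatter. No evidence is available to account for either step. As far as these compounds go, whether chlorine, a hydroxyl or an amine on this carbon would keep or lose activity remains open.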